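Aryl amide variation on a shared sulfonamide core

The source may hold more compounds than are shown below. What is called first, only, known or untested is meant among the compounds shown, and "the series" means these compounds.

Compound 1 `CCOC1=C(/C(C)=N/OCC(=O)Nc2cccc(OC)c2)N(C)S(=O)(=O)c2ccccc21`: > 20000 nM
Compound 2 `CCOC1=C(/C(C)=N/OCC(=O)Nc2ccc(OC)cc2)N(C)S(=O)(=O)c2ccccc21`: > 20000 nM
Compound 3 `CCOC1=C(/C(C)=N/OCC(=O)Nc2ccc(F)c(Cl)c2)N(C)S(=O)(=O)c2ccccc21`: > 20000 nM

In a functional assay on THP-1 cells (Homo sapiens) for inhibition, read by ELISA, with stated times of 2 h and 48 h (on this read-out higher numbers stand for weaker inhibition and lower numbers for stronger inhibition), compound 2 gives > 20000 nM, which is a limit of the assay rather than a number. Compound 1 likewise gives only a limit. Compound 3 also gives only a limit. The steps a step that the two limits leave unreadable from compound 1 to compound 2, a step that the two limits leave unreadable from compound 1 to compound 3 and a step that the two limits leave unreadable from compound 2 to compound 3 therefore cannot be sized, because of the limit of > 20000 nM in this assay, at which 3 of the 3 values shown sit.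

Compound 4 `CCOC1=C(/C(C)=N/OCC(=O)Nc2ccc(Cl)c(C(F)(F)F)c2)N(C)S(=O)(=O)c2ccccc21` differs from compound 2 by 4-chloro-3-(trifluoromethyl)phenyl in place of 4-methoxyphenyl on an amide-type nitrogen. Going by the values given here, no measured step is readable, so no direction can be drawn from the earlier aryl changes. Compound 4 is expected to give 20000 nM, with a range from 8000 nM to 60000 nM, most likely again reported as a limit. The expected step of a number no higher from compound 2 to compound 4 (the limit leaves the size open) is thus none beyond the scatter.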

Compound 4, half-maximal inhibitory concentration: > 20000 nM
Compound 4 gave a limit, no number (the forecaster's own chance of this, stated with the estimate: 80%); the middle value lies on the limit itself.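

The steps from compounds 1, 2 and 3 to compound 4 cannot be read, because all four compounds give only a limit: the limit of > 20000 nM in this assay, at which 4 of the 4 values shown sit.

The compounds shown leave open which aryl amide on the shared core, if any, would give a measurable value.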